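Thiophen-2-yl for 4-methylphenyl: will compound 3 stay non-toxic?

This account rests on a few compounds, and the source may have more. Where it says the series, first, only, none or still open, it means among the compounds named here.

Compound 1 `CC1=C(C(=O)Nc2ccccc2Cl)C(c2ccc(C)cc2)NC(=O)N1` was tested in an ADME assay on Vero cells (Chlorocebus sabaeus) for cytotoxicity, read by XTT assay, with a stated time of 72 h; on this read-out higher numbers stand for lower toxicity in this test and lower numbers for higher toxicity in this test. In this assay compound 1 gives only a limit, > 100000 nM, so its standing is known solely as the limit of > 100000 nM in this assay, at which 1 of the 2 values shown sits. Compound 2 `CCCOC(=O)C1=C(C)NC(=S)NC1c1cccs1`, built on a different core, gives 23600 nM in this assay. Compound 3 `CC1=C(C(=O)Nc2ccccc2Cl)C(c2cccs2)NC(=O)N1` differs from compound 1 by thiophen-2-yl in place of 4-methylphenyl on a saturated ring carbon. Within the data shown here, no measured step covers this change, and no shift beyond the scatter is expected. Compound 3 is therefore expected to give 100000 nM in this assay, with a range from 30000 nM to 300000 nM. This expectation amounts to a step of a number no higher from compound 1 to compound 3 (the limit leaves the size open).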

Compound 3, half-maximal cytotoxic concentration: > 100000 nM
Compound 3: no number, only a limit; the forecaster's own chance of this, stated with the estimate: 60%; the middle value lies on the limit itself.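

Compound 1 and compound 3 both give only a limit in this assay, and the step between them cannot be read. The compounds shown leave open whether thiophen-2-yl in place of 4-methylphenyl shifts the cytotoxic concentration at all.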